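A few compounds are considered here, and "the series" means these few. Any claim that something is new, unique, unknown or untested is made for them only; others in the source may bear on it.

The measured compounds, in a functional assay on the whole organism (blood) with Rattus norvegicus as the target, with stated times of 24 h and 1 h, at a dose of 5 mg/kg by the intraperitoneal route; a lower number here means a weaker effect, a higher number a stronger effect of the compound at the dose given:
compound 1 `COc1ccc(Cl)cc1C(=O)NCCC1CCN(S(=O)(=O)NC(=O)NC2CCCCC2)CC1` gives 25%
compound 2 `COc1ccc(Cl)cc1C(=O)NCCC1CCN(S(=O)(=O)NC(=O)NC[C@@H]2C[C@@H]3C=C[C@@H]2C3)CC1` gives 37%
compound 3 `COc1ccc(Cl)cc1C(=O)NCCC1CCN(S(=O)(=O)NC(=O)NN2CCCCCC2)CC1` gives 36%

Compound 2 holds the largest of the three numbers, but the gap to compound 3 is within the scatter, so the two cannot be placed in order; only against compound 1 is there a real difference, the step being a number 12 percentage points higher from compound 1 to compound 2 (beyond the scatter). Compound 3 likewise stands apart from compound 1, by a number 11 percentage points higher from compound 1 to compound 3 (beyond the scatter), while the comparison of compound 2 with compound 3 reads a number 1 percentage points lower from compound 2 to compound 3 (within the scatter).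

Compound 4 `O=C(NC[C@@H]1C[C@@H]2C=C[C@@H]1C2)NS(=O)(=O)N1CCC(CCNC(=O)c2nc3ccccc3s2)CC1` differs from compound 2 at the opposite end of the shared core: 1,3-benzothiazol-2-yl in place of 5-chloro-2-methoxyphenyl on a carbonyl carbon. Among the measured compounds shown here, no measured step bears on this change. All three steps recorded so far concern the group on the amide-type nitrogen, and the group on the carbonyl carbon is the same in every measured compound, so there is nothing in the data to say whether the new group helps or hurts. The step from compound 2 to compound 4 is therefore expected to be a number 4 percentage points lower from compound 2 to compound 4 (within the scatter), that is, nothing beyond the scatter, with a wide range to reflect the lack of a comparable example. Compound 4 is estimated at 33%, between 15% and 52%.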

Compound 4, a percentage reported as activity, at one dose (the size of the read-out at that dose, not a potency): 24%
Compound 4: the middle estimate sits 9 percentage points above what was measured; measured number inside the range.
By their numbers in this assay, from the lowest: compounds 4 and 1 (each within the scatter of the next); then compounds 3 and 2 (each within the scatter of the next).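

Among the compounds shown here, this is the first reading of the group on the carbonyl carbon, which was the same in all the earlier compounds. In this assay, putting 1,3-benzothiazol-2-yl in place of 5-chloro-2-methoxyphenyl gives a number 13 percentage points lower from compound 2 to compound 4 (beyond the scatter), so this position responds to the group placed there, even though both groups have the same number of heavy atoms. The change alters several things at once, removing the chlorine and the methoxy oxygen and bringing in a five-membered aromatic ring with nitrogen and sulfur, and no measurement available here shows which of these accounts for the lower number.

As far as these compounds go, it remains open whether 1,3-benzothiazol-2-yl would give a similar step with cyclohexyl or azepan-1-yl on the amide-type nitrogen in place of the present group. Also open, from the compounds shown here alone, is how a plain phenyl, a 5-chlorophenyl-type ring without the methoxy, or a 2-methoxyphenyl without the chlorine would read on the same carbonyl carbon, which would help separate the contributions of the two substituents.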